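Methoxy to hydroxy on the dichlorophenyl urea: tolerance outlook

The source may report more compounds than this note shows. Statements on the series, on what has been measured and on what is new or still open speak of the compounds shown alone.

Compound 3 `COc1cc(-c2nn(-c3cccc(NC(=O)Nc4ccc(Cl)c(Cl)c4)c3)cc2-c2ccncc2)ccc1Cl` is one of three close analogues tested in a functional assay on UO-31 cells (Homo sapiens) for inhibition, read by sulforhodamine B assay, with a stated time of 48 h; a higher number here means that more compound is tolerated, a lower number that less compound is tolerated. Compound 3 returns only a limit of the assay, > 50000 nM. Compound 2 `COc1cc(-c2nn(-c3cccc(NC(=O)c4cccc(C(F)(F)F)c4)c3)cc2-c2ccncc2)ccc1Cl` likewise returns only a limit, > 50000 nM. Compound 1 `O=C(Nc1cccc(-n2cc(-c3ccncc3)c(-c3ccc(Cl)c(O)c3)n2)c1)Nc1cccc(C(F)(F)F)c1` also returns only a limit, > 32500 nM. Going by the values given here, the single step among measured pairs, a step that the two limits leave unreadable from compound 2 to compound 3, runs between two limits and cannot be read. Compound 3 therefore stands at a limit alongside both other values, as the limit of > 50000 nM in this assay, at which 2 of the 3 values shown sit, and the limit of > 32500 nM in this assay, at which 1 of the 3 values shown sits, record.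

Compound 4 `O=C(Nc1cccc(-n2cc(-c3ccncc3)c(-c3ccc(Cl)c(O)c3)n2)c1)Nc1ccc(Cl)c(Cl)c1` differs from compound 3 by hydrogen in place of methyl on an oxygen on an aromatic ring. Among the compounds with values here, no measured step covers this change; compound 1 carries the same hydroxy group but with a different urea partner, so nothing here quantifies the exchange. Within the data shown here, with every value shown being a limit, there is no basis for a step in this assay in either direction, and a further limit is the likeliest outcome. The step from compound 3 to compound 4 is expected to be an at least 1.2-fold lower number from compound 3 to compound 4 (0.09 log units; that floor lies within the scatter). Compound 4 is estimated at 40000 nM, with a range from 15000 nM to 100000 nM.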

Compound 4, concentration lethal to 50% of the cells: > 32500 nM
Compound 4 ended at the assay's limit (the forecaster's own chance of this, stated with the estimate: 75%); the middle value does not contradict the limit.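

Compound 4 returns only a limit in this assay, > 32500 nM. The steps to it from compound 3 and from compound 1 both run between limits and cannot be read. The compounds shown leave open whether methoxy to hydroxy, or either urea partner, changes the tolerated concentration at all.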